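One Methoxy Less: From Compound 2 to Compound 3

The source may hold more compounds than are shown below. What is called first, only, known or untested is meant among the compounds shown, and "the series" means these compounds.

compound 1 `COc1cc(-c2cc(/C=C/C(=O)c3ccc(N)cc3)[nH]n2)cc(OC)c1OC` — 90%
compound 2 `COc1ccc(C(=O)/C=C/c2cc(-c3cc(OC)c(OC)c(OC)c3)n[nH]2)cc1OC` — 95%

In a functional assay on MDA-MB-435 cells (Homo sapiens) for cytotoxicity, read by sulforhodamine B assay, with a stated time of 48 h, tested at 0.01 uM (on this read-out lower numbers stand for a stronger effect and higher numbers for a weaker effect at the one concentration tested), compound 1 gives 90%, and compound 2 gives 95%. Compound 2 stands highest of the two numbers, with compound 1 nearest; the step of a number 5 percentage points higher from compound 1 to compound 2 (within the scatter), which put 3,4-dimethoxyphenyl in place of 4-aminophenyl on a carbonyl carbon, lies within the scatter. Both measured compounds therefore show little effect at the one concentration tested.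

Compound 3 `COc1ccc(C(=O)/C=C/c2cc(-c3cc(OC)c(OC)c(OC)c3)n[nH]2)cc1` differs from compound 2 in one place: hydrogen in place of methoxy on an aromatic carbon. Cut one bond further out, this reads 3,4-dimethoxyphenyl to 4-methoxyphenyl, so the change sits on the same ring that was exchanged between compound 1 and compound 2. For the measured compounds named here, that exchange, a larger one, moved the number only within the scatter, and no measured step removes a single methoxy. On this basis the step of a number 3 percentage points lower from compound 2 to compound 3 (within the scatter) is expected to stay within the scatter, with no set direction. Compound 3 is accordingly estimated at 92%, in a range from 78% to 102%.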

Compound 3, a percentage reported as activity, at one concentration (the size of the read-out at that concentration, not a potency): 99%
Estimate against measurement, compound 3: 7 percentage points below; the range from low to high includes it.
By their numbers in this assay, from the lowest: compounds 1, 2 and 3 (each within the scatter of the next).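

In this assay, for the compounds shown here, the step of a number 4 percentage points higher from compound 2 to compound 3 (within the scatter) lies within the scatter, so this is the first reading of a single methoxy on its own: on this aromatic carbon, ortho to a methoxy group, methoxy and hydrogen give numbers that cannot be told apart. The step of a number 9 percentage points higher from compound 1 to compound 3 (within the scatter) also stays within the scatter and narrows the earlier exchange of whole rings to one group on an aromatic carbon, with methoxy in place of amino making no readable difference. At this one concentration, the 3,4-dimethoxyphenyl, 4-methoxyphenyl and 4-aminophenyl groups therefore cannot be separated, and nothing available accounts for the numbers.

All three numbers lie at the high end of this read-out, which stands for little effect, so these compounds cannot show whether the ring matters under conditions where an effect appears, such as at a higher concentration. On these data alone, it also remains open whether a hydroxyl group, a fluorine atom or a longer chain such as ethoxy on this aromatic carbon would give a number beyond the scatter.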